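The source may report more compounds than this note shows. Statements on the series, on what has been measured and on what is new or still open speak of the compounds shown alone.

Measured so far in an assay on isolated protein for inhibition of proto-oncogene tyrosine-protein kinase receptor Ret variant V804L (Homo sapiens), read by 33P incorporation, with stated times of 15 min and 40 min; on this read-out higher numbers stand for weaker inhibition and lower numbers for stronger inhibition:
- compound 1 `O=C(Nc1ccc(Nc2ncnc3c2OCCN3)cc1)Nc1ccc(C(F)(F)F)cc1`: 2470 nM
- compound 2 `COc1cccc(NC(=O)Nc2ccc(Nc3ncnc4c3OCCN4)cc2)c1`: > 10000 nM
- compound 3 `O=C(Nc1ccc(Nc2ncnc3c2OCCN3)cc1)Nc1cccc2ccccc12`: > 10000 nM

Among the measured compounds shown here, compound 1 holds the only numerical value in this assay; the two other values are a limit of the assay (the limit of > 10000 nM in this assay, at which 2 of the 3 values shown sit). For compound 2 the value is such a limit, and for compound 3 likewise, so the step that the two limits leave unreadable from compound 2 to compound 3 cannot be read.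

Both measured steps bear on the change at the same position. The step of an at least 4.0-fold higher number from compound 1 to compound 2 (0.60 log units; beyond the scatter) and the step of an at least 4.0-fold higher number from compound 1 to compound 3 (0.60 log units; beyond the scatter) each replace the 4-(trifluoromethyl)phenyl on the amide-type nitrogen and each weaken inhibition beyond the scatter, so this position tolerates the two alternatives tried poorly.

Compound 4 `CC(C)(C)c1csc(NC(=O)Nc2ccc(Nc3ncnc4c3OCCN4)cc2)n1` carries the change (4-(tert-butyl)-1,3-thiazol-2-yl in place of 4-(trifluoromethyl)phenyl on an amide-type nitrogen). Unlike the 3-methoxyphenyl and the naphthalen-1-yl, the group entering keeps a hydrophobic substituent at the far end of the ring, in the tert-butyl; the ring itself becomes a five-membered heteroaromatic. For the measured compounds named here, with no measured step on a heteroaromatic ring here, a step within the scatter from compound 1 is expected, with a wide band allowing for loss toward the limit: compound 4 is estimated at 2000 nM, between 400 nM and 10000 nM, which means an expected step of a 1.2-fold lower number from compound 1 to compound 4 (0.09 log units; within the scatter).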

Compound 4, half-maximal inhibitory concentration: > 10000 nM
Compound 4: only a limit was reported (the forecaster's own chance of this, stated with the estimate: 30%); at least 5.0-fold (0.69 log units) between middle value and limit.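

In this assay, the 4-(tert-butyl)-1,3-thiazol-2-yl group on the amide-type nitrogen gives an at least 4.0-fold higher number from compound 1 to compound 4 (0.60 log units; beyond the scatter), so the loss at this position now reaches a five-membered aromatic ring with 2 hetero atoms as well as the carbon-only aromatic groups of the earlier replacements. All three replacements of the 4-(trifluoromethyl)phenyl shown so far weaken inhibition beyond the scatter, with no exception among the four compounds, and the presence of a tert-butyl on the entering ring does not exempt compound 4. Compounds 2, 3 and 4 all stand at a limit of the assay rather than at a number, so the steps among these three cannot be read: the limit of > 10000 nM in this assay, at which 3 of the 4 values shown sit.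

On these data alone, how far each of these three lies past the limit, and their order, remains open. Also open, as far as these compounds go, is whether 4-(tert-butyl)phenyl or 4-chlorophenyl on the same nitrogen would stay close to compound 1, which would separate the change of ring from the change of the group the ring carries.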